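From methoxy to nitro on the aromatic ring

A few compounds are considered here, and "the series" means these few. Any claim that something is new, unique, unknown or untested is made for them only; others in the source may bear on it.

Of the compounds shown here, two on the shared core have been read so far in an ADME assay on HeLa cells (Homo sapiens) for cytotoxicity, read by MTT assay; on this read-out lower numbers stand for stronger inhibition and higher numbers for weaker inhibition. Compound 1 (`N#Cc1c(-c2cccc(Cl)c2)c(C#N)c(=O)n(/N=C/c2cn(-c3ccccc3)nc2-c2ccccc2)c1N`) gives > 200 ug/mL, which is a limit and not a number. Compound 2 (`COc1ccc(-c2c(C#N)c(N)n(/N=C/c3cn(-c4ccccc4)nc3-c3ccccc3)c(=O)c2C#N)cc1`) gives > 200 ug/mL, which is also a limit and not a number. Both measured compounds therefore stand at the limit of > 200 ug/mL in this assay, at which 2 of the 2 values shown sit. Within the data shown here, the only measured step, a step that the two limits leave unreadable from compound 1 to compound 2, offers no size to carry forward. Compound 3 (`N#Cc1c(-c2ccc([N+](=O)[O-])cc2)c(C#N)c(=O)n(/N=C/c2cn(-c3ccccc3)nc2-c2ccccc2)c1N`) has nitro in place of methoxy on an aromatic carbon, para to a large group: nitro in place of methoxy on an aromatic carbon. Among the measured compounds shown here, no measured step bears on this change with a readable size, so no step beyond the scatter is expected in this assay, and no direction is expected. The estimated change is a number no higher from compound 2 to compound 3 (the limit leaves the size open). Compound 3 is expected at 200 ug/mL, with an estimated range from 100 ug/mL to 400 ug/mL.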

Compound 3, half-maximal inhibitory concentration: > 200 ug/mL
Compound 3 was reported as a limit; the forecaster's own chance of this, stated with the estimate: 70%; the middle value sits exactly at the limit.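

In this assay compound 3 gives > 200 ug/mL, a limit and not a number. Compound 1 and compound 2 are also limits, so the steps among these three compounds cannot be read. The compounds shown leave open whether 3-chlorophenyl, 4-methoxyphenyl and 4-nitrophenyl differ at all in this assay.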